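Extending the chain on the shared core: a cytotoxicity estimate

This account rests on a few compounds, and the source may have more. Where it says the series, first, only, none or still open, it means among the compounds named here.

Measured so far, in an ADME assay on RD cells (Homo sapiens) for cytotoxicity, read by MTT assay, with a stated time of 24 h; on this read-out higher numbers stand for lower toxicity in this test and lower numbers for higher toxicity in this test:
compound 1, `Cc1nc(-c2ccc(OCCC(C)CCN3CCN(c4ccnc(N)c4)C3=O)cc2)no1`, gives 66100 nM.
compound 2, `CCCc1nc(-c2ccc(OCCC(C)CCN3CCN(c4ccnc(N)c4)C3=O)cc2)no1`, reaches only a limit of the test, > 100000 nM.
compound 3, `Cc1nc(-c2cc(C)c(OCCC(C)CCN3CCN(c4ccnc(N)c4)C3=O)c(C)c2)no1`, gives 28800 nM.

Compound 3 stands lowest of the two numbers that were read, and compound 1 sits a clear step above it, beyond the usual scatter. The third value, that of compound 2, is a limit and not a number, and the limit of > 100000 nM in this assay, at which 1 of the 3 values shown sits, marks where it sits.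

Within the data shown here, the one step that can be weighed is the change (ethyl in place of hydrogen on a saturated chain carbon bound to an aromatic carbon); it brought an at least 1.5-fold higher number from compound 1 to compound 2 (0.17 log units; that floor lies within the scatter). How the core of compound 3 differs from that of compound 1 is not broken down here.

Compound 4, `CCCc1nc(-c2cc(C)c(OCCC(C)CCN3CCN(c4ccnc(N)c4)C3=O)c(C)c2)no1`, carries the same change as compound 2 relative to its parent: ethyl in place of hydrogen on a saturated chain carbon bound to an aromatic carbon. The place is the same in both pairs, so this is the same change again. For compound 4 the expected step is a 1.7-fold higher number from compound 3 to compound 4 (0.24 log units; within the scatter), a guess resting on compound 2, whose result after the same change was an at least 1.5-fold higher number from compound 1 to compound 2 (0.17 log units; that floor lies within the scatter). Compound 4 is therefore estimated at 50000 nM, within a range from 20000 nM to 120000 nM.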

Compound 4, half-maximal cytotoxic concentration: 14100 nM
Compound 4: the middle estimate sits 3.5-fold (0.55 log units) above what was measured; measured number outside the range, below it.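

In this assay, the change from methyl to propyl brought a 2.0-fold lower number from compound 3 to compound 4 (0.31 log units; beyond the scatter), so on this core the propyl compound gives the lower number and reads as the more toxic of the pair. Set beside the earlier step, the same change did not carry over unchanged from one core to the other: the same change on two cores in this assay, an at least 1.5-fold higher number (0.17 log units; that floor lies within the scatter) from compound 1 to compound 2 and a 2.0-fold lower number (0.31 log units; beyond the scatter) from compound 3 to compound 4, at least 3.0-fold (0.48 log units) apart, beyond the scatter of two such steps The value of compound 2 is a limit and not a number, so the earlier step is known only as a floor, and two pairs show neither why the steps part nor how the change would run on a further core: the limit of > 100000 nM in this assay, at which 1 of the 4 values shown sits.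

The compounds shown leave open whether a butyl or other longer chain in place of the propyl would follow the course of compound 2 or that of compound 4. They also leave open whether an amine or a carboxylic acid at the end of such a chain would give a similar split between the two cores.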